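Swapping an aryl ring for a morpholine amide

A few compounds are considered here, and "the series" means these few. Any claim that something is new, unique, unknown or untested is made for them only; others in the source may bear on it.

This account follows two measured compounds and one still unmeasured. Compound 1 `COC(=O)c1cccc(-c2cnc(C(=O)CCCCCCc3ccccc3)o2)c1` and compound 2 `O=C(CCCCCCc1ccccc1)c1ncc(-c2ccc(F)cc2)o1` share a common core and were tested in an assay (Rattus norvegicus) for inhibition of Fatty-acid amide hydrolase 1 (Homo sapiens); on this read-out higher numbers stand for weaker inhibition and lower numbers for stronger inhibition. Compound 1 gives 12 nM in this assay, while compound 2 gives 62 nM. Of the two numbers shown, compound 2 stands at the highest, and its nearest neighbour, compound 1, lies at a lower number by a margin that goes beyond the usual scatter.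

Among the measured compounds shown here, the next compound, compound 3 `O=C(CCCCCCc1ccccc1)c1ncc(C(=O)N2CCOCC2)o1`, differs from compound 2 in one place. (morpholin-4-yl)carbonyl in place of 4-fluorophenyl on an aromatic carbon No measured pair in this set tracks that kind of change, so there is no step between known compounds to lean on; what remains is that the two measured values differ only in their aryl substituent, which says little about replacing the aryl ring altogether. The step of a 2.4-fold higher number from compound 2 to compound 3 (0.38 log units; beyond the scatter) is therefore expected to be modest and toward higher numbers, though a result inside the scatter would not surprise. For compound 3 the estimated result in this assay is 150 nM, with a range from 30 nM to 700 nM.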

Compound 3, inhibition constant: 24 nM
For compound 3 the middle estimate is 6.3-fold (0.80 log units) above the measured one, and the stated range ends above it.
By their numbers in this assay, from the lowest: compounds 1 and 3 (each within the scatter of the next); then compound 2.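

In this assay the exchange gives a 2.6-fold lower number from compound 2 to compound 3 (0.41 log units; beyond the scatter), which shows that an aromatic ring of carbon only is not needed on this aromatic carbon, next to the ring oxygen, for a number in this range. The earlier compounds shown here carried only aryl groups here, whereas compound 3 carries a six-membered non-aromatic ring with 2 hetero atoms, attached through a carbonyl, and the value of compound 3 at 24 nM lies within the scatter of compound 1 at 12 nM. Nothing measured in this set speaks to why the number moved.

The compounds shown leave open whether the step belongs to the carbonyl or to the morpholine ring, a question that a piperidine amide, a dimethylamide, a methyl ester or a carboxylic acid on this aromatic carbon would help to separate. They also leave open whether the (morpholin-4-yl)carbonyl group would give a similar step on a shorter or longer chain than the phenyl-bearing chain shared by all three compounds.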